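Oxime against ketone on a triazole thioether series

The source may hold more compounds than are shown below. What is called first, only, known or untested is meant among the compounds shown, and "the series" means these compounds.

Compound 1 `C=CCn1c(SCC(=O)c2ccccc2)nnc1-c1ccc(OC)c(OC)c1`: 62%
Compound 2 `CCn1c(SCC(=O)c2ccccc2)nnc1-c1cc(OC)c(OC)c(OC)c1`: 59%
Compound 3 `CCn1c(SC/C(=N/O)c2ccccc2)nnc1-c1ccc(OC)c(OC)c1`: 71%

In a functional assay on the whole organism (strain albino) for inhibition, with Rattus norvegicus as the target, read by paw edema, with a stated time of 5 h, at a dose of 0.28 mmol/kg by the oral route (a higher number here means more inhibition at the dose given (going by the name of the read-out), a lower number less inhibition), compound 3 gives the highest of the three numbers, 71%. Its nearest neighbour is compound 1, whose 62% lies within the usual scatter of it, so no order between compound 3 and compound 1 can be claimed. Compound 2, with 59%, lies furthest from compound 3 and beyond the scatter.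

Compound 4 `CCn1c(SCC(=O)c2ccccc2)nnc1-c1ccc(OC)c(OC)c1` has not been measured in this assay. It differs from compound 3 in one place: a group of 8 heavy atoms (7 carbon, 1 oxygen; one six-membered aromatic ring of carbon only) in place of a group of 9 heavy atoms (7 carbon, 1 nitrogen, 1 oxygen; one six-membered aromatic ring of carbon only), on a saturated chain carbon bound to a sulfur. The change turns the side chain of compound 3 into the benzoyl-bearing chain shared by compound 1 and compound 2, both of which sit below compound 3 in this assay.

For the measured compounds named here, no measured pair shows this exact change, so the expected step rests on the position of compound 1 and compound 2 alone. Compound 4 is expected to move from compound 3 by a number 10 percentage points lower from compound 3 to compound 4 (within the scatter), a small drop that may itself stay within the scatter. Compound 4 is therefore estimated at 61% in this assay, with a range from 50% to 72%.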

Compound 4, a percentage reported as inhibition, in the whole organism at one dose (the size of the read-out at that dose, not a potency): 69%
The estimate for compound 4 lay 8 percentage points below the measured number, and the stated range covers the measured number.
By their numbers in this assay, from the lowest: compounds 2, 1, 4 and 3 (each within the scatter of the next, the first and the last beyond it).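

In this assay, the benzoyl group in place of the oxime-bearing group on a saturated chain carbon bound to a sulfur gives a number 2 percentage points lower from compound 3 to compound 4 (within the scatter), so at this position the two groups cannot be told apart, and the carbonyl of the benzoyl group shows no loss against the oxime. The two other changes that now connect to compound 4 also stay within the scatter: hydrogen in place of methoxy on an aromatic carbon gives a number 10 percentage points higher from compound 2 to compound 4 (within the scatter), and methyl in place of vinyl on a saturated chain carbon bound to an aromatic nitrogen gives a number 7 percentage points higher from compound 1 to compound 4 (within the scatter). No single change shown here therefore moves the number beyond the scatter, and no measurement of any property of these groups is available to account for the size of these steps.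

As far as these compounds go, it remains open whether a carboxylic acid or an amine on that saturated chain carbon bound to a sulfur would fall within the same scatter as the benzoyl group and the oxime-bearing group. From the compounds shown here alone, it is equally open how a longer chain in place of the methyl would read, and whether these steps would stay this small at another dose or reading time.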